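The source may report more compounds than this note shows. Statements on the series, on what has been measured and on what is new or still open speak of the compounds shown alone.

Compound 2 `CC(C)c1onc(-c2c(Cl)cccc2Cl)c1COc1ccc(-c2nc3ccc(C(=O)O)cc3n2CC2CC2)cc1` gives 29.1 nM in an assay on isolated protein for agonist activity at Bile acid receptor (Homo sapiens), read by TR-FRET; a lower number here means that less compound is needed, a higher number that more compound is needed for the effect. Among the two compounds measured so far it holds the highest number, but its only neighbour, compound 1 `CCC(CC)n1c(-c2ccc(OCc3c(-c4c(Cl)cccc4Cl)noc3C(C)C)cc2)nc2ccc(C(=O)O)cc21` with 26.5 nM in this assay, sits within the scatter of it, so the two cannot be told apart. Within the data shown here, the one measured step, a 1.1-fold higher number from compound 1 to compound 2 (0.04 log units; within the scatter), swaps one group on the aromatic nitrogen for another and leaves the number essentially unchanged.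

Compound 3 `CC(C)c1onc(-c2c(Cl)cccc2Cl)c1COc1ccc(-c2nc3ccc(C(=O)O)cc3n2C(C)C)cc1` is the next compound to be measured. Its difference from compound 2 is isopropyl in place of cyclopropylmethyl on an aromatic nitrogen. This change sits at the same aromatic nitrogen as the step from compound 1 to compound 2, and that step stayed within the scatter. On that basis compound 3 is expected to show no step beyond the scatter, a 1.0-fold higher number from compound 2 to compound 3 (0.01 log units; within the scatter), in this assay. The estimate for compound 3 is therefore 30 nM, with a range from 15 nM to 60 nM.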

Compound 3, half-maximal effective concentration: 56.7 nM
Compound 3: the middle estimate sits 1.9-fold (0.28 log units) below what was measured; low and high end bracket the measured number.
By their numbers in this assay, from the lowest: compounds 1, 2 and 3 (each within the scatter of the next, the first and the last beyond it).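

Among these compounds, at this aromatic nitrogen, the group can now be seen to matter a little: isopropyl in place of pentan-3-yl gives a 2.1-fold higher number from compound 1 to compound 3 (0.33 log units; beyond the scatter) in this assay and is the first step here to pass the scatter, though only modestly. Isopropyl and cyclopropylmethyl still cannot be told apart, with a 1.9-fold higher number from compound 2 to compound 3 (0.29 log units; within the scatter) so the position shows a small effect between the two outer compounds and none that can be resolved between neighbours. Nothing available explains this difference.

Going by these compounds, it remains open how far the number can move at this nitrogen, and in which direction, when the group is changed more sharply. A methyl, a cyclohexyl ring or a longer chain ending in an amine would test this more widely than these three closely related carbon groups.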